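Notes on the step from compound 2 to compound 4

The compounds below may be only part of what the source reports. "The series", "measured", "known", "first", "only" and "open" are said of these compounds alone.

Measured so far:
compound 1, `COc1ccc(-c2cc(/C=C/C(=O)c3ccc(OC)c(OC)c3)[nH]n2)cc1`, 10600 nM
compound 2, `COc1cc(-c2cc(/C=C/C(=O)c3ccc(Cl)c(Cl)c3)[nH]n2)cc(OC)c1OC`, > 100000 nM
compound 3, `COc1ccc(-c2cc(/C=C/C(=O)c3ccc(N)cc3)[nH]n2)cc1OC`, 36300 nM

All three were run in a functional assay on OVCAR-5 cells (Homo sapiens) for inhibition, read by sulforhodamine B assay, with a stated time of 48 h; on this read-out lower numbers stand for higher toxicity in this test and higher numbers for lower toxicity in this test. Compound 1 gives 10600 nM and compound 3 gives 36300 nM. Compound 2 returns only a limit of the assay, > 100000 nM, and no number is known for it. Of the three values shown, it is the one that sits at the limit of > 100000 nM in this assay, at which 1 of the 3 values shown sits.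

Compound 4, `COc1cc(-c2cc(/C=C/C(=O)c3ccc(F)c(F)c3)[nH]n2)cc(OC)c1OC`, has not yet been measured in this assay. It differs from compound 2 in one place: 3,4-difluorophenyl in place of 3,4-dichlorophenyl on a carbonyl carbon. The 3,4-dichlorophenyl leaves, the 3,4-difluorophenyl enters, and the rest of the structure is unchanged. Going by the values given here, no pair of measured compounds differs in a single place, so these data give no measured size for any step, and none for a halogen exchange in particular.

The step from compound 2 to compound 4 in this assay, an at least 1.2-fold lower number from compound 2 to compound 4 (0.09 log units; that floor lies within the scatter), is expected to stay within the usual scatter of the method, with the estimate placed just inside the reportable range. Compound 4 is therefore estimated at 80000 nM, between 25000 nM and 200000 nM, with a real chance that this assay again reports only a limit.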

Compound 4, concentration lethal to 50% of the cells: > 100000 nM
Compound 4 gave a limit, no number; the forecaster's own chance of this, stated with the estimate: 45%; middle value at least 1.2-fold (0.09 log units) from the limit.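

In this assay compound 4 gives > 100000 nM as a limit of the assay, not a number. Going by these compounds alone, compound 2 likewise gives > 100000 nM as a limit, so no step between compound 2 and compound 4 can be read. On these data alone, whether 3,4-difluorophenyl and 3,4-dichlorophenyl on a carbonyl carbon differ in this assay remains open.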